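The source may report more compounds than this note shows. Statements on the series, on what has been measured and on what is new or still open speak of the compounds shown alone.

Three compounds measured in a functional assay on HCT-116 cells (Homo sapiens) for inhibition, read by luminescence and resazurin assay, with a stated time of 3 days (on this read-out lower numbers stand for stronger inhibition and higher numbers for weaker inhibition), share a core and differ in the small group on one ring nitrogen and in the way the amide is joined. Compound 1 `CCCNc1nc(NCc2ccc(NC(=O)c3ccc(F)cc3)cc2)c2ccccc2n1` gives 1700 nM. Compound 2 `CCNc1nc(NCc2ccc(C(=O)Nc3ccc(F)cc3)cc2)c2ccccc2n1` gives 1900 nM. Compound 3 `O=C(Nc1ccc(F)cc1)c1ccc(CNc2nc(NC3CC3)nc3ccccc23)cc1` gives 2700 nM. The three numbers sit close together; compound 3 gives the highest of them, but its gaps to compound 2 and to compound 1 both lie within the usual spread of repeat measurements, so no ordering among them can be read with confidence.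

Compound 4 `CCCNc1nc(NCc2ccc(C(=O)Nc3ccc(F)cc3)cc2)c2ccccc2n1` arises from compound 3 by the change (propyl in place of cyclopropyl on a nitrogen on an aromatic ring). Going by the values given here, the only measured step that bears on this place is the exchange of ethyl for cyclopropyl, which gave a 1.4-fold higher number from compound 2 to compound 3 (0.15 log units; within the scatter), a shift too small to count. Because the step of a 1.4-fold higher number from compound 2 to compound 3 (0.15 log units; within the scatter) was within the scatter, swapping one three-carbon group for another at the same nitrogen is expected to move this assay little, if at all. The step from compound 3 to compound 4 is therefore estimated at a 1.3-fold lower number from compound 3 to compound 4 (0.11 log units; within the scatter). For compound 4 the expected value in this assay is 2100 nM, with a likely range from 1000 nM to 4500 nM.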

Compound 4, half-maximal inhibitory concentration: 1500 nM
Compound 4: middle estimate off by 1.4-fold (0.15 log units), on the high side; the range from low to high includes it.
By their numbers in this assay, from the lowest: compounds 4, 1, 2 and 3 (each within the scatter of the next).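

Replacing cyclopropyl with propyl on this nitrogen gives a 1.8-fold lower number from compound 3 to compound 4 (0.26 log units; within the scatter) in this assay and shows that removing the three-membered ring, with the count of carbons unchanged, has no effect that can be read here. Lengthening the chain from ethyl to propyl gives a 1.3-fold lower number from compound 2 to compound 4 (0.10 log units; within the scatter) and adds a direct comparison along the chain, so ethyl, cyclopropyl and propyl cannot be told apart at this nitrogen in this assay. Going by these compounds alone, compound 4 also links the two amide arrangements for the first time, since compound 1 and compound 2 differed in two places; with propylamino held fixed, the single change gives a 1.1-fold lower number from compound 1 to compound 4 (0.05 log units; within the scatter) and so the direction of the amide has no readable effect either.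

The compounds shown leave open whether any group on this nitrogen can move the number beyond the scatter, for example a longer chain such as hexyl, a bare amino group or a chain ending in a carboxylic acid. No measurement here explains why these steps are all so small.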